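Compound 4: isopropyl amide in the shared core series

The compounds below may be only part of what the source reports. "The series", "measured", "known", "first", "only" and "open" are said of these compounds alone.

Of the compounds shown here, three on the shared core have been measured in a functional assay for inhibition of nuclear factor NF-kappa-B complex (Homo sapiens); a lower number here means a stronger inhibitor, a higher number a weaker inhibitor. Compound 1 `COc1ccc2c(c1)OC(c1cc(OC)c(OC)c(OC)c1)C(C(=O)NC(C)(C)C)=C2` gives 28400 nM and holds the highest of the two numbers recorded, with compound 2 `COc1ccc2c(c1)OC(c1cc(OC)c(OC)c(OC)c1)C(C(=O)OCCc1ccccc1)=C2` nearest at 16200 nM; the step of a 1.8-fold lower number from compound 1 to compound 2 (0.24 log units; within the scatter) lies within the scatter. Compound 3 `COc1ccc2c(c1)OC(c1cc(OC)c(OC)c(OC)c1)C(C(=O)O)=C2` gives only a limit of the assay, > 50000 nM, as noted in the limit of > 50000 nM in this assay, at which 1 of the 3 values shown sits. The steps of an at least 1.7-fold higher number from compound 1 to compound 3 (0.24 log units; that floor lies within the scatter) and an at least 3.0-fold higher number from compound 2 to compound 3 (0.48 log units; beyond the scatter) show that the free acid is at best the weakest member, the second of these lying beyond the scatter.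

Compound 4 `COc1ccc2c(c1)OC(c1cc(OC)c(OC)c(OC)c1)C(C(=O)NC(C)C)=C2` differs from compound 1 by hydrogen in place of methyl on a saturated chain carbon bound to an amide-type nitrogen and two saturated chain carbons. Going by the values given here, no measured step varies the amide substituent itself, so none bears directly on this change; the only amide replacements recorded are the ester of compound 2 and the acid of compound 3, which stay within or barely beyond the scatter of compound 1. The expected step of a 1.1-fold higher number from compound 1 to compound 4 (0.02 log units; within the scatter) is therefore none beyond the scatter. Compound 4 is estimated at 30000 nM, with a range of 12000 nM to 65000 nM.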

Compound 4, half-maximal inhibitory concentration: > 50000 nM
Compound 4 gave a limit, no number; the forecaster's own chance of this, stated with the estimate: 25%; middle value at least 1.6-fold (0.22 log units) away from the limit.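

In this assay compound 4 gives > 50000 nM, which is a limit of the assay and not a number: the limit of > 50000 nM in this assay, at which 2 of the 4 values shown sit. This is the first reading on the amide substituent itself, and the change from tert-butyl to isopropyl comes out as an at least 1.7-fold higher number from compound 1 to compound 4 (0.24 log units; that floor lies within the scatter), so no loss of inhibition beyond the scatter is shown for removing that methyl. Replacing the ester with the isopropyl amide gives an at least 3.0-fold higher number from compound 2 to compound 4 (0.48 log units; beyond the scatter), so the phenethyl ester of compound 2 now stands apart from a secondary amide as well as from the free acid.

Compound 3 and compound 4 both stand at limits, and the step between them cannot be read. From the compounds shown here alone, whether a phenethyl group on the amide nitrogen, or a longer chain there, would bring a readable number stays open.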